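Ortho-substituted benzyl triazole: from bromo limit to chloro

The compounds below may be only part of what the source reports. "The series", "measured", "known", "first", "only" and "open" are said of these compounds alone.

Series of four benzyl triazoles on a shared core, read in a functional assay on HeLa cells (Homo sapiens) for cytotoxicity, read by MTT assay, with a stated time of 48 h; on this read-out higher numbers stand for weaker inhibition and lower numbers for stronger inhibition. Compound 1 `O=c1ccoc2cc(OCc3cn(Cc4ccc(Cl)cc4)nn3)ccc12` gives 37600 nM. Compound 2 `Cc1ccccc1Cn1cc(COc2ccc3c(=O)ccoc3c2)nn1` gives 15300 nM. Compound 3 `O=c1ccoc2cc(OCc3cn(Cc4ccc(Br)cc4)nn3)ccc12` gives only a limit of the assay, > 100000 nM, so compound 3 stands at the weak end of the numbers shown; it is the one value sitting at the limit of > 100000 nM in this assay, at which 1 of the 3 values shown sits. Compound 4 `O=c1ccoc2cc(OCc3cn(Cc4ccccc4Cl)nn3)ccc12` is not yet measured.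

The change from compound 3 to compound 4 is 2-chlorophenyl in place of 4-bromophenyl on a saturated chain carbon bound to an aromatic nitrogen. Among the measured compounds shown here, two measured steps bear on it. The bromo-to-chloro exchange on the aromatic carbon gave an at least 2.6-fold higher number from compound 1 to compound 3 (0.42 log units; beyond the scatter), so returning to chloro should at least recover that ground. The move from a 4-substituted to a 2-substituted phenyl gave a 2.5-fold lower number from compound 1 to compound 2 (0.39 log units; beyond the scatter), and from compound 2 to compound 3 the step was an at least 6.5-fold higher number from compound 2 to compound 3 (0.81 log units; beyond the scatter). Both point the same way: a step down in number, at least modest, is expected for compound 4, estimated as an at least 4.0-fold lower number from compound 3 to compound 4 (0.60 log units; beyond the scatter). Whether 2-chlorophenyl behaves like 2-methylphenyl rather than like 4-chlorophenyl is not resolved by the three measured compounds, which widens the range. Compound 4 is therefore expected to give 25000 nM, with a range from 9000 nM to 90000 nM.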

Compound 4, half-maximal inhibitory concentration: > 100000 nM
Compound 4: only a limit was reported (the forecaster's own chance of this, stated with the estimate: 20%); middle value at least 4.0-fold (0.60 log units) from the limit.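

In this assay compound 4 gives > 100000 nM, which is a limit of the assay and not a number. The place of the chloro matters at this position, since 2-chlorophenyl in place of 4-chlorophenyl gives an at least 2.6-fold higher number from compound 1 to compound 4 (0.42 log units; beyond the scatter), and the 2-substituted phenyl does not by itself keep activity, since chloro in place of methyl on an aromatic carbon gives an at least 6.5-fold higher number from compound 2 to compound 4 (0.81 log units; beyond the scatter). The step between compound 3 and compound 4 cannot be read, and of the benzyl groups shown only those of compound 1 and compound 2 stay measurable: the limit of > 100000 nM in this assay, at which 2 of the 4 values shown sit.

As far as these compounds go, how far compound 3 and compound 4 lie past the limit remains unknown, so 2-chlorophenyl and 4-bromophenyl cannot be ranked against each other. Also open, from the compounds shown here alone, is whether the measurable number of compound 2 is particular to 2-methylphenyl or extends to 2-methoxyphenyl or 2-fluorophenyl, and how a phenyl carrying an amine or a carboxylic acid, or a longer chain in place of the benzyl carbon, would read.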